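Methoxy Added to Compound 2: No Gain Expected

A few compounds are considered here, and "the series" means these few. Any claim that something is new, unique, unknown or untested is made for them only; others in the source may bear on it.

Measured compounds in a functional assay on Bel-7402 cells (Homo sapiens) for cytotoxicity, read by MTT assay; on this read-out lower numbers stand for stronger inhibition and higher numbers for weaker inhibition:
Compound 1 `COc1cccc(/C=C/C(=O)c2sc(Nc3cccc(C)c3)nc2C)c1` gives > 25000 nM, a limit of the assay.
Compound 2 `Cc1nc(Nc2cccc(Cl)c2)sc1C(=O)/C=C/c1ccccc1` gives > 25000 nM, likewise a limit of the assay.

Compound 2 therefore stands not at a number but at the edge of what this assay reports; it shares that position with compound 1, since (the limit of > 25000 nM in this assay, at which 2 of the 2 values shown sit). For the measured compounds named here, no step between measured compounds is available. The two measured compounds differ in more than one place.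

Compound 3 `COc1cccc(/C=C/C(=O)c2sc(Nc3cccc(Cl)c3)nc2C)c1` is the next compound to be measured. It differs from compound 2 by methoxy in place of hydrogen on an aromatic carbon. Compound 1 already carries the same methoxy, combined with a methyl rather than a chloro group on the other ring, and compound 1 gives > 25000 nM, a limit. Nothing in the measured values points to the methoxy lifting activity above the limit.

The step from compound 2 to compound 3 is expected to be none beyond the scatter in this assay, the expected step being a step that the limit leaves unreadable from compound 2 to compound 3. Compound 3 is estimated to give about 35000 nM, with a range from 12000 nM to 100000 nM, and most likely to be reported once more as a limit.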

Compound 3, half-maximal inhibitory concentration: > 25000 nM
Compound 3 gave a limit, no number; the forecaster's own chance of this, stated with the estimate: 80%; the middle value does not contradict the limit.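

In this assay, neither the step from compound 2 to compound 3 nor the step from compound 1 to compound 3 can be read, and no size can be given for either: the limit of > 25000 nM in this assay, at which 3 of the 3 values shown sit.

The compounds shown leave open whether methoxy in place of hydrogen, or chloro in place of methyl, changes the read-out at all; none of them gives a number.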